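The compounds below may be only part of what the source reports. "The series", "measured", "known", "first", "only" and "open" are said of these compounds alone.

Of the compounds shown here, three with the same core have been measured in a functional assay on K562 cells (Homo sapiens) for inhibition, read by fluorescence, with a stated time of 72 h; on this read-out higher numbers stand for weaker inhibition of growth and lower numbers for stronger inhibition of growth. Compound 1 (`COc1ccc(Cn2cnc3c(Nc4cccc(Cl)c4)nc(N[C@H]4CC[C@H](N)CC4)nc32)cc1`) gives 2800 nM, the lowest number of the three, but compound 2 (`CCCCn1cnc2c(NCc3cccc(Cl)c3)nc(N[C@H]3CC[C@H](N)CC3)nc21`) at 4300 nM lies within the scatter of it. Compound 3 (`N[C@H]1CC[C@H](Nc2nc(Nc3ccc(O)cc3)c3ncn(C4CCCCC4)c3n2)CC1`) gives 8900 nM, a number beyond the scatter from that of compound 1. The next compound, compound 4 (`CC(C)CCn1cnc2c(Nc3cccc(Cl)c3)nc(N[C@H]3CC[C@H](N)CC3)nc21`), is reached from compound 1 by one change: isobutyl in place of 4-methoxyphenyl on a saturated chain carbon bound to an aromatic nitrogen. Read one bond further out, this is 4-methoxybenzyl giving way to isopentyl, on a saturated chain carbon bound to an aromatic nitrogen. Within the data shown here, no measured pair isolates this change, so the evidence is indirect. Compound 2 also has a chain without a ring in this place and gives 4300 nM, although it differs from compound 1 elsewhere as well. On that basis, only a small move towards a higher number is expected in this assay, with nothing beyond the scatter. The expected change is a 1.3-fold higher number from compound 1 to compound 4 (0.10 log units; within the scatter). For compound 4 the estimated value is 3500 nM, with an expected range from 1500 nM to 8000 nM.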

Compound 4, concentration for 50% growth inhibition: 1500 nM
Estimate against measurement, compound 4: 2.3-fold (0.37 log units) above, and the stated range covers the measured number.
By their numbers in this assay, from the lowest: compounds 4, 1 and 2 (each within the scatter of the next, the first and the last beyond it); then compound 3.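

In this assay, putting isobutyl in place of 4-methoxyphenyl on a saturated chain carbon bound to an aromatic nitrogen gives a 1.9-fold lower number from compound 1 to compound 4 (0.27 log units; within the scatter), and this is the first pair shown that differs at this place alone. It shows that the aromatic ring and its methoxy oxygen can both leave this place, with a chain without a ring taking over, and the number stays within the scatter. No measurement shown accounts for this result.

The compounds shown leave open whether a longer chain, a terminal amine or a carboxylic acid at this place would also stay within the scatter of compound 4 in this assay. They also leave open whether the same exchange would give a similar step on compounds carrying the other groups seen in compound 2 and compound 3.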